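The source may hold more compounds than are shown below. What is called first, only, known or untested is meant among the compounds shown, and "the series" means these compounds.

The measured compounds:
compound 1, `COc1ccc(N/C=C\C(=O)c2cc(OC)c(OC)c(OC)c2Br)cc1`, gives 250 nM in a functional assay on K562 cells (Homo sapiens) for cytotoxicity, read by trypan blue exclusion, with a stated time of 96 h; a lower number here means a stronger inhibitor, a higher number a weaker inhibitor
compound 2, `COc1cc(C(=O)/C=C\Nc2ccc3[nH]ccc3c2)c(Br)c(OC)c1OC`, gives 200 nM in this assay
compound 3, `COc1ccc(N/C=C\C(=O)c2cc(OC)c(OC)c(OC)c2)cc1`, gives 500 nM in this assay

Compound 4, `COc1cc(C(=O)/C=C\Nc2ccc3[nH]ccc3c2)cc(OC)c1OC`, has not yet been measured in this assay. It is built on the core of compound 2 and differs from it in one place: hydrogen in place of bromo on an aromatic carbon. The same change has already been made once among the measured compounds, from compound 1 to compound 3: hydrogen in place of bromo on an aromatic carbon. That step gave a 2.0-fold higher number from compound 1 to compound 3 (0.30 log units; within the scatter). Among the measured compounds shown here, the place of the change is described in exactly the same words for both pairs, so the change from compound 2 to compound 4 is the same change as the one from compound 1 to compound 3.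

The cores of compound 1 and compound 2 differ as follows: 1H-indol-5-yl in place of 4-methoxyphenyl on an amine nitrogen. That change gave a 1.3-fold lower number from compound 1 to compound 2 (0.10 log units; within the scatter), so the numbers of compound 1 and compound 2 cannot be told apart.

For the measured compounds named here, the only guide for compound 4 is therefore the one earlier step, and the expected step is set to match it, because a 2.0-fold higher number from compound 1 to compound 3 (0.30 log units; within the scatter) is the sole measurement of this change. That earlier step makes the expected step from compound 2 to compound 4 a 2.0-fold higher number from compound 2 to compound 4 (0.30 log units; within the scatter). In this assay compound 4 is accordingly estimated to give 400 nM, with a likely range from 200 nM to 800 nM.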

Compound 4, half-maximal inhibitory concentration: 500 nM
Estimate against measurement, compound 4: 1.3-fold (0.10 log units) below, and the stated range covers the measured number.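

Replacing the bromo group with hydrogen on the core of compound 2 gives a 2.5-fold higher number from compound 2 to compound 4 (0.40 log units; beyond the scatter) in this assay, so here the loss of bromo leaves a number that can be told apart from the starting one. Set beside the earlier case, the two steps agree, which means that in this small set the change carries over from one core to the other with much the same size: the same change on two cores in this assay, a 2.0-fold higher number (0.30 log units; within the scatter) from compound 1 to compound 3 and a 2.5-fold higher number (0.40 log units; beyond the scatter) from compound 2 to compound 4, 1.3-fold (0.10 log units) apart, within the scatter of two such steps. Among the compounds shown here, this rests on only two pairs, whose cores differ only in whether the amine nitrogen carries 4-methoxyphenyl or 1H-indol-5-yl, and one of the two steps lies within the scatter on its own, so it shows neither that the same size would hold on other cores nor why bromo and hydrogen give different numbers.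

On this aromatic carbon, only bromo and hydrogen appear among the compounds shown, which leaves open how a chloro group, a methyl group or a nitrile would compare. Going by these compounds, it also remains open whether the step would keep its size with a different group on the amine nitrogen, such as a simple alkyl chain.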